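Paw edema inhibition: swapping the aryl group on compound 2

The source may hold more compounds than are shown below. What is called first, only, known or untested is meant among the compounds shown, and "the series" means these compounds.

Measured compounds:
Compound 1 `COc1ccc(C2CC(c3ccc(Cl)cc3)=NN2c2nc3ccc(S(N)(=O)=O)cc3s2)cc1`: 67.7%
Compound 2 `NS(=O)(=O)c1ccc2nc(N3N=C(c4ccc(Cl)cc4)CC3c3ccccc3Cl)sc2c1`: 14%

In a functional assay on the whole organism (strain Wistar) for inhibition, with Rattus norvegicus as the target, read by paw edema, with stated times of 1 h and 5 h, at a dose of 20 mg/kg by the oral route (on this read-out lower numbers stand for less inhibition and higher numbers for more inhibition at the one dose given (going by the name of the read-out)), compound 2 gives 14%, the lowest of the two numbers shown; compound 1 stands higher at 67.7%. Within the data shown here, the one measured step, a number 53.7 percentage points lower from compound 1 to compound 2 (beyond the scatter), brought in the 2-chlorophenyl that now leaves. Compound 3 `CN(C)c1ccc(C2CC(c3ccc(Cl)cc3)=NN2c2nc3ccc(S(N)(=O)=O)cc3s2)cc1` differs by 4-(dimethylamino)phenyl in place of 2-chlorophenyl on a saturated ring carbon. Since this undoes the change that bears on compound 2 and in size was large, compound 3 is expected to rise by a number 41 percentage points higher from compound 2 to compound 3 (beyond the scatter). Compound 3 is therefore estimated at 55%, within 30% to 75%.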

Compound 3, a percentage reported as inhibition, in the whole organism at one dose (the size of the read-out at that dose, not a potency): 14%
Compound 3: middle estimate off by 41 percentage points, on the high side; the whole stated range lies above it.
By their numbers in this assay, from the lowest: compounds 2 and 3 (each within the scatter of the next); then compound 1.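

In this assay, 4-(dimethylamino)phenyl in place of 2-chlorophenyl on the saturated ring carbon gave no change at the digits printed from compound 2 to compound 3 (within the scatter), so removing the 2-chlorophenyl did not by itself restore the response. Dimethylamino in place of methoxy on an aromatic carbon gave a number 53.7 percentage points lower from compound 1 to compound 3 (beyond the scatter), which shows that the higher response of compound 1 does not carry over to this other 4-substituted phenyl. Nothing available here explains either step. The compounds shown leave open whether an ethoxy or hydroxy group in place of methoxy, or an unsubstituted phenyl, would keep the response of compound 1.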